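The source may hold more compounds than are shown below. What is called first, only, known or untested is meant among the compounds shown, and "the series" means these compounds.

Compound 2 `O=C(Nc1ccc(Nc2cc(Cl)nc(SC(C(=O)O)c3cccc4ccccc34)n2)cc1)c1ccccc1` gives 5200 nM in an assay on isolated protein for inhibition of Polyunsaturated fatty acid 5-lipoxygenase (Homo sapiens) (a higher number here means a weaker inhibitor, a lower number a stronger inhibitor), which places it at the upper end of the two numbers recorded, though compound 1 `O=C(O)C(Sc1nc(Cl)cc(Nc2cccc(Cl)c2)n1)c1cccc2ccccc12` with 5000 nM lies within the scatter of it, so the two cannot be separated. Compound 3 `O=C(O)C(Sc1nc(Cl)cc(Nc2ccc(C3CCCCC3)cc2)n1)c1cccc2ccccc12` departs from compound 2 by cyclohexyl in place of benzamido on an aromatic carbon. Among the measured compounds shown here, no measured pair isolates this change, so the expected step in this assay is small, with no direction beyond the scatter; the estimated step is a 1.2-fold lower number from compound 2 to compound 3 (0.06 log units; within the scatter). Compound 3 is therefore expected to give about 4500 nM in this assay, within the range 1500 nM to 14000 nM.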

Compound 3, half-maximal inhibitory concentration: 2000 nM
Estimate against measurement, compound 3: 2.3-fold (0.35 log units) above; the measured number falls inside the stated range.
By their numbers in this assay, from the lowest: compound 3; then compounds 1 and 2 (each within the scatter of the next).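

Cyclohexyl in place of benzamido at this aromatic carbon gives the first step beyond the scatter in this assay (a 2.6-fold lower number from compound 2 to compound 3 (0.41 log units; beyond the scatter)), so this position does respond to its substituent, if only modestly. Inhibition also survives without the amide and its hydrogen-bond donor and acceptor. No measurement here bears on why the number fell. The amide and the aromatic ring of benzamido leave together, so their separate shares cannot be told apart. As far as these compounds go, how a morpholine, a tert-butyl group or a carboxylic acid would fare at this carbon remains open.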